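Oxime ether series: 2-chloroethyl for isopropyl at the oxygen

A few compounds are considered here, and "the series" means these few. Any claim that something is new, unique, unknown or untested is made for them only; others in the source may bear on it.

Compound 3 `C#CCc1c(Cl)cc(N/C=N/OC(C)C)cc1Cl` gives 3.9 in a physicochemical assay for lipophilicity, measured as octanol-water partition (a lower number here means a more polar compound, a higher number a more lipophilic compound), the lowest of the three numbers in hand. Compound 2 `CC#CCOc1c(Cl)cc(N/C=N/OCC)cc1Cl` gives 4 in this assay, a gap from compound 3 that stays within the scatter of such measurements. Compound 1 `CCO/N=C/Nc1cc(Cl)c(OCC(C)C)c(Cl)c1` gives 5 in this assay, a gap from compound 3 that lies beyond the scatter. Among the compounds with values here, the single step measured so far, a number 1.00 log units lower from compound 1 to compound 2 (beyond the scatter), concerns a change on the saturated chain carbon bound to an oxygen on the aromatic ring, not the oxygen carried by the double-bonded nitrogen, so it offers no direct guide here.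

Compound 4 `C#CCc1c(Cl)cc(N/C=N/OCCCl)cc1Cl` differs from compound 3 by 2-chloroethyl in place of isopropyl on an oxygen. The leaving and entering groups match in heavy-atom count, neither carries a hydrogen-bond donor or acceptor, and neither is charged. Within the data shown here, with no measured step at this place, the expectation rests on that balance alone: a step of a number 0.20 log units lower from compound 3 to compound 4 (within the scatter) is expected, which is within the scatter and so no real change. Compound 4 is therefore estimated at 3.7 in this assay, with a range from 3.2 to 4.2.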

Compound 4, partition coefficient: 3.7
Beside the measured number, compound 4's estimate shows no gap at the digits printed, within the range that was stated.
By their numbers in this assay, from the lowest: compounds 4, 3 and 2 (each within the scatter of the next); then compound 1.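

Within the data shown here, at the oxygen whose other neighbour is the double-bonded nitrogen, the reading in this assay is a number 0.20 log units lower from compound 3 to compound 4 (within the scatter) and gives the first measured step at this place, since the earlier step concerned the saturated chain carbon bound to the oxygen on the aromatic ring. On the core of compound 3, 2-chloroethyl in place of isopropyl, or isopropoxy to 2-chloroethoxy when the same difference is cut one bond further out, therefore leaves the two compounds unresolved in this read-out, with the count of 3 heavy atoms the same in both groups. No supporting measurement is available to explain this result.

The compounds shown leave open whether a longer chain such as n-butyl, or an amine such as 2-aminoethyl, at this oxygen would give a step beyond the scatter in this assay on the same core. They also leave open whether 2-chloroethyl in place of isopropyl would read the same way on a core carrying the ring substituents of compound 1 or compound 2.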